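This account rests on a few compounds, and the source may have more. Where it says the series, first, only, none or still open, it means among the compounds named here.

Measured compounds:
Compound 1, `O=C(Nc1cccc(CNc2nccnc2Cl)c1)NC1CCCCC1`: in a functional assay on MGC-803 cells (Homo sapiens) for antiproliferative activity, read by MTT assay, with a stated time of 48 h (a higher number here means a weaker inhibitor, a lower number a stronger inhibitor), compound 1 reaches only the assay limit > 40000 nM.
Compound 2, `Cc1ccc(NC(=O)Nc2cccc(CNc3nccnc3Cl)c2)c(C)c1`: in this assay compound 2 gives 10100 nM.

Compound 2 thus carries the only numerical result in this assay; the other result is a limit of the assay, (the limit of > 40000 nM in this assay, at which 1 of the 2 values shown sits). Among the measured compounds shown here, the single measured step, an at least 3.9-fold lower number from compound 1 to compound 2 (0.59 log units; beyond the scatter), is the only comparison available, and it concerns a different exchange at the same nitrogen.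

The unmeasured compound 3, `CCc1ccccc1NC(=O)Nc1cccc(CNc2nccnc2Cl)c1`, differs from compound 2 in one place: 2-ethylphenyl in place of 2,4-dimethylphenyl on an amide-type nitrogen. For the measured compounds named here, no measured step matches this exchange. The step from compound 1 to compound 2 traded cyclohexyl for 2,4-dimethylphenyl, whereas here one group is replaced by another built from the same atoms joined differently, so that step bears on the present change only loosely. On this basis no change beyond the scatter is expected, a 1.2-fold higher number from compound 2 to compound 3 (0.07 log units; within the scatter). Compound 3 is estimated at 12000 nM, with a range from 4500 nM to 32000 nM.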

Compound 3, half-maximal inhibitory concentration: 9370 nM
Compound 3: middle estimate off by 1.3-fold (0.11 log units), on the high side, within the range that was stated.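

Among the compounds shown here, the exchange of 2,4-dimethylphenyl for 2-ethylphenyl on the amide-type nitrogen gives a 1.1-fold lower number from compound 2 to compound 3 (0.03 log units; within the scatter), so in this assay these two arrangements of the same atoms cannot be told apart, something the earlier compounds could not show. The exchange of cyclohexyl for 2-ethylphenyl gives an at least 4.2-fold lower number from compound 1 to compound 3 (0.63 log units; beyond the scatter), which repeats at this nitrogen what an at least 3.9-fold lower number from compound 1 to compound 2 (0.59 log units; beyond the scatter) showed, so the gain over cyclohexyl now holds for two different substituted phenyl groups, with neither compound going against it. The result for compound 1 is a limit of the assay and not a number, so both steps from it have only a lower bound on their size: the limit of > 40000 nM in this assay, at which 1 of the 3 values shown sits.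

The compounds shown leave open whether an unsubstituted phenyl group would give a number in the same range as compound 2 and compound 3, and whether a single methyl group would be enough. They also leave open what a pyridine ring, a methoxy group, a halogen or a longer chain at this nitrogen would do to the number in this assay.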